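This account rests on a few compounds, and the source may have more. Where it says the series, first, only, none or still open, it means among the compounds named here.

Working notes on the series. Compound 1 `Cc1cc(C)cc(S(=O)(=O)c2c(C(=O)NCC(=O)NCc3ccco3)[nH]c3ccc(Cl)cc23)c1` and compound 2 `Cc1cc(C)cc(S(=O)(=O)c2c(C(=O)NC(C)c3ccco3)[nH]c3ccc(Cl)cc23)c1` share the same core and differ only at the amide-type nitrogen. In an ADME assay on MT4 cells (Homo sapiens) for cytotoxicity, read by MTT assay (a lower number here means that less compound is tolerated, a higher number that more compound is tolerated), compound 1 gives > 50000 nM, which is a limit of the assay rather than a number, (the limit of > 50000 nM in this assay, at which 1 of the 2 values shown sits). In this assay compound 2 gives > 54700 nM, likewise a limit, (the limit of > 54700 nM in this assay, at which 1 of the 2 values shown sits). Within the data shown here, the only step in the set, a step that the two limits leave unreadable from compound 1 to compound 2, is therefore without a readable size. On the numbers shown, compound 1 stands at a limit only, with nothing placed either side of it.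

Compound 3 `Cc1cc(C)cc(S(=O)(=O)c2c(C(=O)NCC(=O)NC(C)c3ccccc3F)[nH]c3ccc(Cl)cc23)c1` is still to be measured in this assay. It differs from compound 1 by 1-(2-fluorophenyl)ethyl in place of (furan-2-yl)methyl on an amide-type nitrogen. Among the measured compounds shown here, the one measured step that bears on changes at this nitrogen gives no size, so there is no basis for expecting any step beyond the scatter in either direction. Compound 3 is therefore expected, like the two measured compounds, to sit near or at the limit. The expected step of a number no higher from compound 1 to compound 3 (the limit leaves the size open) is read as none beyond the scatter. The estimate for compound 3 in this assay is 50000 nM, with a range from 20000 nM to 110000 nM.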

Compound 3, half-maximal cytotoxic concentration: 23000 nM
The estimate for compound 3 lay 2.2-fold (0.34 log units) above the measured number, and the stated range covers the measured number.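

In this assay, among these compounds, changes on this amide-type nitrogen are not all silent: 1-(2-fluorophenyl)ethyl in place of (furan-2-yl)methyl gives an at least 2.1-fold lower number from compound 1 to compound 3 (0.33 log units; beyond the scatter), the first step in the set with a readable size, and it runs towards less compound being tolerated. Compound 1, the starting point of that step, is a limit and not a number: the limit of > 50000 nM in this assay, at which 1 of the 3 values shown sits.

Among the compounds shown here, the single change replaces a five-membered aromatic ring with 1 hetero atom by a six-membered aromatic ring of carbon only, and it also brings in fluorine, so this step alone cannot assign the shift to any one of these differences.

Open, going by these compounds, is whether the shift follows the fluorine or the carbon-only ring, which a plain 1-phenylethyl or a 1-(furan-2-yl)ethyl at this same nitrogen would help to separate. Also open, on these data alone, is how far the number moves with a group of another kind here, such as a carboxylic acid or an amine on a longer chain.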